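The source may report more compounds than this note shows. Statements on the series, on what has been measured and on what is new or still open speak of the compounds shown alone.

Measured so far in a functional assay on HEK293 cells for agonist activity at 5-hydroxytryptamine receptor 4 (Homo sapiens), read by cAMP accumulation; on this read-out lower numbers stand for an effect already at smaller amounts and higher numbers for an effect only at larger amounts of compound:
- compound 1 `COc1cc(N)c(Cl)cc1C(=O)NC1CCN(CCCCCCCCO)CC1`: 15.9 nM
- compound 2 `COc1cc(N)c(Cl)cc1C(=O)NC1CCN(CCCCCCCCN2C(=O)c3ccccc3C2=O)CC1`: 3.16 nM
- compound 3 `COc1cc(N)c(Cl)cc1C(=O)NC1CCN(CCN2CCN(S(C)(=O)=O)CC2)CC1`: 20 nM

Compound 1 stands second highest of the three numbers; its nearest neighbour is within the usual scatter, its furthest a modest step away. The unmeasured compound 4 `COc1cc(N)c(Cl)cc1C(=O)NC1CCN(CCCCCN2CCN(S(C)(=O)=O)CC2)CC1` differs from compound 1 by 4-(methylsulfonyl)piperazin-1-yl in place of 3-hydroxypropyl on a saturated chain carbon, five bonds along the chain from an amine nitrogen in a ring. Going by the values given here, two measured steps bear on this change. One is a 1.3-fold higher number from compound 1 to compound 3 (0.10 log units; within the scatter), which brings in the same ring group on a shorter chain and stays within the scatter. The other is a 5.0-fold lower number from compound 1 to compound 2 (0.70 log units; beyond the scatter), where a larger group at the chain end gave a modest gain. A small shift toward lower numbers, or none beyond the scatter, is therefore expected: a 1.3-fold lower number from compound 1 to compound 4 (0.12 log units; within the scatter). Compound 4 is estimated at 12 nM in this assay, with a range from 4 nM to 35 nM.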

Compound 4, half-maximal effective concentration: 12.6 nM
Compound 4: middle estimate off by 1.1-fold (0.02 log units), on the low side; the range from low to high includes it.
By their numbers in this assay, from the lowest: compound 2; then compounds 4, 1 and 3 (each within the scatter of the next).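

In this assay, 4-(methylsulfonyl)piperazin-1-yl in place of 3-hydroxypropyl, five bonds along the chain from an amine nitrogen in a ring, gives a 1.3-fold lower number from compound 1 to compound 4 (0.10 log units; within the scatter). This position therefore takes the bulkier ring group without a change beyond the scatter, and the same group two bonds along the chain gives a value within the scatter too: compound 3 reads 20 nM and compound 4 reads 12.6 nM. No evidence here explains this result.

On these data alone, whether a basic amine or a carboxylic acid at this chain end, or a longer chain carrying the same ring, would shift the number beyond the scatter remains open.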